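Dropping one chloro from a dichloropurine benzyl series

The source may hold more compounds than are shown below. What is called first, only, known or untested is meant among the compounds shown, and "the series" means these compounds.

Compound 1 `ClCc1ccc(Cn2cnc3nc(Cl)nc(Cl)c32)cc1` has been tested in a functional assay on BT-549 cells (Homo sapiens) for cytotoxicity, read by sulforhodamine B assay, with a stated time of 48 h (on this read-out higher numbers stand for weaker inhibition of growth and lower numbers for stronger inhibition of growth), where compound 1 gives 3460 nM. Within the data shown here, of the two numbers available, it is the one compared against compound 2 `ClCc1cccc(Cn2cnc3c(Cl)nc(Cl)nc32)c1`, which in this assay gives 3230 nM; the gap between these two values lies within the usual scatter of repeated measurements, so the two compounds are not distinguished by this read-out. Compound 3 `ClCc1ccc(Cn2cnc3ncnc(Cl)c32)cc1` has not yet been measured in this assay. It differs from compound 1 in one place: hydrogen in place of chloro on an aromatic carbon. Among the measured compounds shown here, no measured pair in this set isolates the loss of a chloro, so there is no direct precedent for the size of this step. Compound 1 gives 3460 nM and compound 2 gives 3230 nM, both carrying two chloro groups on the shared core. Against this background, compound 3 is expected to give a somewhat higher number, with the step estimated at a 1.6-fold higher number from compound 1 to compound 3 (0.20 log units; within the scatter), though a result within the scatter cannot be excluded. Compound 3 is therefore expected to give 5500 nM in this assay, with a range from 1800 nM to 17000 nM.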

Compound 3, concentration for total growth inhibition: 17000 nM
Compound 3: the middle estimate sits 3.1-fold (0.49 log units) below what was measured; low and high end bracket the measured number.
By their numbers in this assay, from the lowest: compounds 2 and 1 (each within the scatter of the next); then compound 3.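

In this assay, among these compounds, the step, a 4.9-fold higher number from compound 1 to compound 3 (0.69 log units; beyond the scatter), is the first comparison in this set that isolates a single change, and it lies beyond the scatter. It shows that the chloro on this aromatic carbon between two ring nitrogen atoms matters to growth inhibition in this series: with everything else in compound 1 held fixed, hydrogen in its place gives a clearly weaker result, and the chloro group that remains in compound 3 does not preserve the number of compound 1. Nothing at hand explains why this change moves the number.

On these data alone, whether an amine, a methoxy group or a fluoro at this same carbon would keep the number close to that of compound 1, or move it further in either direction, remains open. Also open, as far as these compounds go, are whether hydrogen in place of the remaining chloro group, the one meta to this carbon, would produce a step of similar size, and whether the same change made on compound 2 would do so.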